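Removing the vinyloxy group from the bromopyridine of compound 2

This account rests on a few compounds, and the source may have more. Where it says the series, first, only, none or still open, it means among the compounds named here.

Two compounds of the series have numbers in a functional assay on HEK293 cells for agonist activity at Neuronal acetylcholine receptor; alpha4/beta2 (Homo sapiens), read by FLIPR and calcium flux (on this read-out lower numbers stand for an effect already at smaller amounts and higher numbers for an effect only at larger amounts of compound), so far. Compound 1 `c1cncc(N2CCCNCCC2)c1` carries the unsubstituted pyridine on the shared core; in this assay compound 1 gives 36.3 nM. Compound 2 `C=COc1cc(N2CCCNCCC2)cnc1Br` carries both a bromo group and a vinyloxy group on the pyridine; in this assay compound 2 gives 240 nM. Compound 2 thus stands at the highest of the two numbers, and its nearest neighbour, compound 1, sits well outside the scatter of it.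

The next compound, compound 3 `Brc1ccc(N2CCCNCCC2)cn1`, keeps the bromo group of compound 2 and differs from it only in one place: hydrogen in place of vinyloxy on an aromatic carbon. Among the compounds with values here, no measured pair shows this change on its own, so the size of the step cannot be read off. Against compound 1, compound 3 differs only by the bromo group, and the two measured numbers of compound 1 and compound 2 bracket what a bromopyridine without the vinyloxy group might give.

For compound 3 the expectation is a number nearer to that of compound 1 than to that of compound 2, an estimated step of a 3.0-fold lower number from compound 2 to compound 3 (0.48 log units; beyond the scatter). Compound 3 is therefore estimated at 80 nM, with a range from 25 nM to 300 nM.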

Compound 3, half-maximal effective concentration: 1.29 nM
Estimate against measurement, compound 3: 62-fold (1.79 log units) above; measured number below the stated range.
By their numbers in this assay, from the lowest: compound 3; then compound 1; then compound 2.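

In this assay the bromo group and the vinyloxy group can now each be read on their own, one place at a time. Hydrogen in place of vinyloxy on the aromatic carbon ortho to the bromo group gives a 190-fold lower number from compound 2 to compound 3 (2.27 log units; beyond the scatter), while bromo in place of hydrogen gives a 28-fold lower number from compound 1 to compound 3 (1.45 log units; beyond the scatter), so both single changes are large and both end at compound 3. The high number of compound 2 therefore goes with the vinyloxy group at this position and not with the bromo group, which goes with a lower number than hydrogen when compared on the otherwise unchanged core; the data in hand offer no measured ground for either step.

As far as these compounds go, it remains open whether the vinyloxy group carries the same penalty on a ring without the bromo group, and whether only its vinyl part or the whole group matters at this position, as a methoxy group or an amine there would show. Equally open, from the compounds shown here alone, is whether the gain belongs to bromo in particular or would also come with chloro or a methyl group in its place.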